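Acetamido for aminomethyl on the hydroxamate series

The source may report more compounds than this note shows. Statements on the series, on what has been measured and on what is new or still open speak of the compounds shown alone.

Compound 1 `NCc1ccc(C(=O)NO)cc1` and compound 2 `O=C(NO)c1ccc(Cc2noc(-c3ccccc3)n2)cc1` share the hydroxamic acid core and have been measured in an assay on Sf9 cells for inhibition of protein deacetylase HDAC6 (Homo sapiens), read by fluorescence; on this read-out higher numbers stand for weaker inhibition and lower numbers for stronger inhibition. In this assay compound 1 gives 695 nM, the higher of the two numbers; compound 2 gives 6 nM, a gap that lies well beyond the scatter. Going by the values given here, no pair differing in a single place has been measured, so no step size is known from the series itself.

Compound 3 `CC(=O)Nc1ccc(C(=O)NO)cc1` is the next entry. Its change from compound 1 is acetamido in place of aminomethyl on an aromatic carbon. Among the compounds with values here, nothing measured so far shows how this assay responds to this exchange; the only reference is compound 1 at 695 nM. The expectation is a small step, if any, toward weaker inhibition, with a step of about a 1.7-fold higher number from compound 1 to compound 3 (0.24 log units; within the scatter) estimated. Compound 3 is therefore expected to give about 1200 nM in this assay, with a likely range from 350 nM to 4000 nM.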

Compound 3, half-maximal inhibitory concentration: 270 nM
Compound 3: the middle estimate sits 4.4-fold (0.65 log units) above what was measured, outside the stated range (below it).
By their numbers in this assay, from the lowest: compound 2; then compound 3; then compound 1.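

In this assay, going by these compounds alone, the change to acetamido in place of aminomethyl, para to a hydroxycarbamoyl group, gives a 2.6-fold lower number from compound 1 to compound 3 (0.41 log units; beyond the scatter) and so provides the first step of known size at this position. The position accepts the larger acetamido group, with 4 heavy atoms against 2, and inhibition does not weaken; the counts of hydrogen-bond donors and acceptors and the net charge are the same for both groups, so these counts alone do not follow the step. No measurement shown explains the step.

Still open, going by these compounds, is how a carboxylic acid, a plain amine or a longer acyl chain on the amide nitrogen would behave at this place. Compound 2, at 6 nM, differs from compound 3 in more than one place, so what separates them cannot be assigned to any single group.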